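Notes on aryl amide variation of the shared core

The source may hold more compounds than are shown below. What is called first, only, known or untested is meant among the compounds shown, and "the series" means these compounds.

Measured so far:
compound 1, `O=C(Nc1ccc2nc(NC(=O)C3CCCCC3)sc2c1)c1ccccc1F`: 0.14 ug/mL
compound 2, `O=C(Nc1ccc2nc(NC(=O)C3CCCCC3)sc2c1)c1ccccc1C(F)(F)F`: 0.024 ug/mL
compound 3, `O=C(Nc1ccc2nc(NC(=O)C3CCCCC3)sc2c1)c1ccc(Cl)cc1Cl`: a limit only, > 4 ug/mL

In a functional assay on WI-38 VA13 cells (Homo sapiens) for cytotoxicity (a higher number here means that more compound is needed for the effect, a lower number that less compound is needed), compound 2 gives 0.024 ug/mL, the lowest of the two numbers; its nearest neighbour is compound 1, with a 5.8-fold lower number from compound 1 to compound 2 (0.77 log units; beyond the scatter). Compound 3 reaches only the limit of this assay, and that limit is the limit of > 4 ug/mL in this assay, at which 1 of the 3 values shown sits.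

Compound 4, `O=C(Nc1ccc2nc(NC(=O)C3CCCCC3)sc2c1)c1c(F)cccc1C(F)(F)F`, differs from compound 2 by fluoro in place of hydrogen on an aromatic carbon. Within the data shown here, two measured steps bear on it: a 5.8-fold lower number from compound 1 to compound 2 (0.77 log units; beyond the scatter), a modest step, and an at least 160-fold higher number from compound 2 to compound 3 (2.22 log units; beyond the scatter), a large step. Compound 4 keeps the trifluoromethyl of compound 2 and only adds a fluoro, so a step of no more than modest size is expected for compound 4 in this assay, estimated as a 1.7-fold higher number from compound 2 to compound 4 (0.22 log units; within the scatter). Compound 4 is expected at 0.04 ug/mL, within 0.012 ug/mL to 0.15 ug/mL.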

Compound 4, half-maximal effective concentration: 0.032 ug/mL
For compound 4 the middle estimate is 1.3-fold (0.10 log units) above the measured one; low and high end bracket the measured number.
By their numbers in this assay, from the lowest: compounds 2 and 4 (each within the scatter of the next); then compound 1. At a limit, above all of these: compound 3.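

In this assay fluoro in place of hydrogen, ortho to a large group and meta to a trifluoromethyl group, gives a 1.3-fold higher number from compound 2 to compound 4 (0.12 log units; within the scatter), so this aromatic carbon takes the added fluoro without a step beyond the scatter. Trifluoromethyl in place of hydrogen gives a 4.4-fold lower number from compound 1 to compound 4 (0.64 log units; beyond the scatter) with the fluoro kept in both structures, so the lower number seen with trifluoromethyl does not rest on losing the fluoro.

From the compounds shown here alone, whether an amine or a carboxylic acid on this aromatic carbon would stay near these numbers remains open. No measured property shown accounts for either step.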